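This account rests on a few compounds, and the source may have more. Where it says the series, first, only, none or still open, it means among the compounds named here.

Compounds measured so far:
- compound 1, `Cc1cccc(Cl)c1NC(=O)CN1CCN(c2nnc(Cc3ccncc3)c3ccccc23)CC1`: 7190 nM
- compound 2, `COc1ccc(NC(=O)CN2CCN(c3nnc(Cc4ccccc4)c4ccccc34)CC2)cc1OC`: "not active" (no number reported)
- compound 3, `Cc1ccc(NC(=O)CN2CCN(c3nnc(Cc4ccccc4)c4ccccc34)CC2)c(C)c1`: "not active" (no number reported)

In a functional assay on A549 cells (Homo sapiens) for cytotoxicity, read by MTT assay, with a stated time of 72 h (a higher number here means a weaker inhibitor, a lower number a stronger inhibitor), compound 1 gives 7190 nM and is the only one of the three with a reported number. In this assay compound 2 gives "not active" (no number reported), and in the same assay compound 3 gives "not active" (no number reported). Nothing about the size of any step between these three can be computed, since two of them carry no number.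

Compound 4, `O=C(CN1CCN(c2nnc(Cc3ccncc3)c3ccccc23)CC1)Nc1cc(C(F)(F)F)ccc1Cl`, has not yet been measured in this assay. It differs from compound 1 in one place: 2-chloro-5-(trifluoromethyl)phenyl in place of 2-chloro-6-methylphenyl on an amide-type nitrogen. The shared core and the linking amide remain unchanged.

Among the measured compounds shown here, with no measured step to lean on, the expectation for compound 4 rests on compound 1 alone, whose value is 7190 nM. The step from compound 1 to compound 4 is expected to be small, a 1.3-fold lower number from compound 1 to compound 4 (0.12 log units; within the scatter), with no direction claimed beyond the scatter. Compound 4 is therefore estimated at 5500 nM, in a range from 1500 nM to 20000 nM.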

Compound 4, half-maximal inhibitory concentration: 1850 nM
Compound 4: the middle estimate sits 3.0-fold (0.47 log units) above what was measured, and the stated range covers the measured number.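

In this assay, the group on the amide-type nitrogen proved able to shift the number: 2-chloro-5-(trifluoromethyl)phenyl in place of 2-chloro-6-methylphenyl gives a 3.9-fold lower number from compound 1 to compound 4 (0.59 log units; beyond the scatter) on an otherwise unchanged compound. Among the compounds shown here, this is the first step that can be read here, as no step to compound 2 or compound 3 can be read without a number. No measurement shown gives a reason for this step.

Because the methyl group leaves and the trifluoromethyl group enters at once, the compounds shown do not separate the contribution of either group. From the compounds shown here alone, it also remains open whether a nitrile or a carboxylic acid in place of the trifluoromethyl group would keep, lose or extend this step.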